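Trifluoromethoxy to methylsulfanyl on the shared core

The source may hold more compounds than are shown below. What is called first, only, known or untested is meant among the compounds shown, and "the series" means these compounds.

Compound 1 `CCC1=C(O)c2c(oc(-c3ccc(C)cc3)cc2=O)C(CC)(CC)C1=O`: 0.08 uM
Compound 2 `CCC1=C(O)c2c(oc(-c3ccc(OC)cc3)cc2=O)C(CC)(CC)C1=O`: 0.68 uM
Compound 3 `CCC1=C(O)c2c(oc(-c3ccc(OC(F)(F)F)cc3)cc2=O)C(CC)(CC)C1=O`: 9.95 uM
Compound 4 `CCC1=C(O)c2c(oc(-c3ccc(SC)cc3)cc2=O)C(CC)(CC)C1=O`: not yet measured

In a functional assay on KBVIN cells (Homo sapiens) for antiproliferative activity, read by sulforhodamine B assay, with a stated time of 3 days (on this read-out higher numbers stand for an effect only at larger amounts of compound and lower numbers for an effect already at smaller amounts), compound 3 gives 9.95 uM, the highest number of the three measured compounds. Compound 4 carries methylsulfanyl in place of trifluoromethoxy on an aromatic carbon. Among the measured compounds shown here, no measured compound holds methylsulfanyl, so the nearest guides are the large steps that introduce trifluoromethoxy, a 15-fold higher number from compound 2 to compound 3 (1.17 log units; beyond the scatter) and a 120-fold higher number from compound 1 to compound 3 (2.09 log units; beyond the scatter). The methyl and methoxy compounds lie closer together, with the modest 8.5-fold higher number from compound 1 to compound 2 (0.93 log units; beyond the scatter). If compound 4 falls near those two, a large step to a lower number is expected. The step expected is a 25-fold lower number from compound 3 to compound 4 (1.40 log units; beyond the scatter). For compound 4 the estimated value is 0.4 uM, with an expected range from 0.08 uM to 2.5 uM.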

Compound 4, concentration for half-maximal effect: 1.38 uM
Beside the measured number, compound 4's estimate is 3.5-fold (0.54 log units) below it, within the range that was stated.
By their numbers in this assay, from the lowest: compound 1; then compound 2; then compound 4; then compound 3.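

In this assay methylsulfanyl on this aromatic carbon gives back much of what trifluoromethoxy loses, with a 7.2-fold lower number from compound 3 to compound 4 (0.86 log units; beyond the scatter) as the gain, but it stays short of methoxy and methyl, with a 2.0-fold higher number from compound 2 to compound 4 (0.31 log units; beyond the scatter) and a 17-fold higher number from compound 1 to compound 4 (1.24 log units; beyond the scatter) as the cost. Sulfur in place of the oxygen of methoxy is thus the smallest step yet seen at this position. On these data alone, whether an amine, a chlorine atom or a longer chain such as ethyl would match methyl here stays open. Nothing given accounts for the order of these four groups.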